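Adding a Methoxy Group to a Pyrazole Chalcone

A few compounds are considered here, and "the series" means these few. Any claim that something is new, unique, unknown or untested is made for them only; others in the source may bear on it.

Measured so far in a functional assay on UACC-62 cells (Homo sapiens) for cytotoxicity, read by sulforhodamine B assay, with a stated time of 48 h, tested at 10 uM; on this read-out higher numbers stand for a weaker effect at the one concentration tested and lower numbers for a stronger effect:
Compound 1 `COc1cc(-c2cc(/C=C/C(=O)c3ccc(Cl)c(Cl)c3)[nH]n2)cc(OC)c1OC` gives 63%.
Compound 2 `COc1ccc(-c2cc(/C=C/C(=O)c3cc(OC)c(OC)c(OC)c3)[nH]n2)cc1OC` gives -61%.
Compound 3 `COc1ccc(C(=O)/C=C/c2cc(-c3cc(OC)c(OC)c(OC)c3)n[nH]2)cc1` gives -74%.

Among these three numbers compound 2 stands second highest. Its nearest neighbour is compound 3, lower by an amount beyond the scatter, and its furthest is compound 1, far higher. Going by the values given here, the only step measured between two compounds that differ in one place is a number 137 percentage points lower from compound 1 to compound 3 (beyond the scatter), a change of the aryl group on the carbonyl carbon. It does not touch the place altered here, so it bears only indirectly on the present step. Compound 4 `COc1cc(C(=O)/C=C/c2cc(-c3cc(OC)c(OC)c(OC)c3)n[nH]2)cc(OC)c1OC` differs from compound 2 by methoxy in place of hydrogen on an aromatic carbon. Among the compounds with values here, compound 2 and compound 3 both give strongly negative numbers with methoxy-bearing aryl groups at either end of the shared core, and no measured step concerns this aromatic carbon. The step of a number 4 percentage points lower from compound 2 to compound 4 (within the scatter) is therefore expected to be small, likely none beyond the scatter. Compound 4 is estimated at -65%, between -85% and -40%.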

Compound 4, a percentage reported as activity, at one concentration (the size of the read-out at that concentration, not a potency): -69%
The estimate for compound 4 lay 4 percentage points above the measured number, and the stated range covers the measured number.
By their numbers in this assay, from the lowest: compounds 3, 4 and 2 (each within the scatter of the next, the first and the last beyond it); then compound 1.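

In this assay the change of hydrogen to methoxy gives a number 8 percentage points lower from compound 2 to compound 4 (within the scatter) and so, at this aromatic carbon, ortho to a methoxy group and meta to a large group, the added methoxy leaves the read-out unchanged within the scatter. Going by these compounds alone, this is the first measured step at this place, and it stands apart from the large step of a number 137 percentage points lower from compound 1 to compound 3 (beyond the scatter) at the aryl group on the carbonyl carbon. No measurement is available to explain why the read-out holds.

Going by these compounds, it remains open whether this aromatic carbon would tolerate an amine, a carboxylic acid or a longer chain such as butoxy as well as it does methoxy. On these data alone, it is also open whether methoxy in place of hydrogen here would give an equally small step with 3,4-dichlorophenyl on the carbonyl carbon.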